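The compounds below may be only part of what the source reports. "The series", "measured", "known", "first", "only" and "open" are said of these compounds alone.

This piece follows one change made to compound 1, `COc1ccc(-c2cnc(NC(=O)c3ccccc3O)n2C)cc1`, and what it may do in a toxicity assay on THP-1 cells (Homo sapiens) for inhibition; on this read-out lower numbers stand for higher toxicity in this test and higher numbers for lower toxicity in this test. In this assay compound 1 reaches only a limit of the test, > 100000 nM, so no number is known for it. Two related compounds tell a similar story. Compound 2, `COc1ccc(-c2nc3ncc(-c4ccc(F)cc4)cc3[nH]2)cc1`, also sits at a limit in this assay, giving > 100000 nM. Compound 3, `Cn1c(-c2ccc(C#N)cc2)cnc1NC(=O)c1ccc(F)cc1`, likewise sits at a limit in this assay, giving > 50000 nM. Together these values show where the measured compounds stand: the limit of > 100000 nM in this assay, at which 2 of the 3 values shown sit, and (the limit of > 50000 nM in this assay, at which 1 of the 3 values shown sits). For the measured compounds named here, no pair among them differs in one place, so no measured step is available. Compound 4, `COc1ccc(-c2cnc(NC(=O)c3ccc(C)cc3)n2C)cc1`, is the unmeasured one. It differs from compound 1 in a single change: 4-methylphenyl in place of 2-hydroxyphenyl on a carbonyl carbon. With all three measured compounds at limits, no step beyond the scatter is expected in this assay. Compound 4 is therefore estimated at 100000 nM, between 50000 nM and 300000 nM. This estimate means a number no higher from compound 1 to compound 4 (the limit leaves the size open), a step expected to stay within the usual scatter.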

Compound 4, half-maximal cytotoxic concentration: > 100000 nM
Compound 4 gave a limit, no number (the forecaster's own chance of this, stated with the estimate: 75%); the middle value lies on the limit itself.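

Compound 1 and compound 4 both stop at a limit of the test, so no step can be read between them. The compounds shown leave open whether 4-methylphenyl in place of 2-hydroxyphenyl changes anything in this assay, where none of them yields an actual number.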